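Benzyloxy to ethoxy: expected change in antiproliferative read-out

The source may hold more compounds than are shown below. What is called first, only, known or untested is meant among the compounds shown, and "the series" means these compounds.

In a functional assay on PC-3 cells (Homo sapiens) for antiproliferative activity, with a stated time of 48 h (on this read-out higher numbers stand for weaker inhibition and lower numbers for stronger inhibition), compound 1 (`COc1cc(O)c(C(=O)/C=C/c2ccccc2)cc1I`) returns > 50000 nM as a limit and not a number. Compound 2 (`COc1ccc(C(=O)/C=C/c2ccccc2)c(O)c1I`) gives 34000 nM and compound 3 (`O=C(/C=C/c1ccccc1)c1ccc(OCc2ccccc2)cc1O`) gives 34700 nM in this assay and these two values lie within the scatter of each other. Compound 3 therefore stands level with compound 2. Relative to compound 3, compound 4 (`CCOc1ccc(C(=O)/C=C/c2ccccc2)c(O)c1`) has methyl in place of phenyl on a saturated chain carbon bound to an oxygen on an aromatic ring with benzyloxy giving way to ethoxy. Among the compounds with values here, no two measured compounds differ in one place, so no measured step sizes this change. The expected step of a 1.0-fold higher number from compound 3 to compound 4 (0.00 log units; within the scatter) in this assay is none beyond the scatter, with no direction favoured. Compound 4 is estimated at 35000 nM with 15000 nM to 70000 nM as the expected range.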

Compound 4, half-maximal inhibitory concentration: 8200 nM
Beside the measured number, compound 4's estimate is 4.3-fold (0.63 log units) above it; the whole stated range lies above it.
By their numbers in this assay, from the lowest: compound 4; then compounds 2 and 3 (each within the scatter of the next). At a limit, above all of these: compound 1.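

Within the data shown here, the first single-place comparison in this assay is ethoxy for benzyloxy, with a 4.2-fold lower number from compound 3 to compound 4 (0.63 log units; beyond the scatter), so inhibition is stronger with methyl than with phenyl on the saturated chain carbon bound to an oxygen on an aromatic ring. Phenyl at this place is therefore not required for activity in this pair. Nothing shown accounts for the size of this step.

Still open, on these data alone, is how the read-out responds to a longer chain or a terminal amine at this place. A single pair also leaves unsettled whether the same step holds on other cores.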